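Shortening the amide chain by one carbon

This account rests on a few compounds, and the source may have more. Where it says the series, first, only, none or still open, it means among the compounds named here.

Compound 1 `CCC(=O)Nc1ccc(N2CCN(c3ccc(OC[C@@H]4CO[C@@](Cn5cncn5)(c5ccc(Cl)cc5Cl)O4)cc3)CC2)cc1`: 2550 nM
Compound 2 `O=C(CCCc1ccccc1)Nc1ccc(N2CCN(c3ccc(OC[C@@H]4CO[C@@](Cn5cncn5)(c5ccc(Cl)cc5Cl)O4)cc3)CC2)cc1`: 3780 nM

Of the compounds shown here, two have been measured in a functional assay on A549 cells (Homo sapiens) for inhibition, read by MTT assay, with a stated time of 48 h; a higher number here means a weaker inhibitor, a lower number a stronger inhibitor. Among the compounds with values here, compound 2 is the only neighbour of compound 1 there, and the one step between them, a 1.5-fold higher number from compound 1 to compound 2 (0.17 log units; within the scatter), does not exceed the scatter, so the two numbers cannot be told apart with confidence.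

Compound 3 `O=C(CCc1ccccc1)Nc1ccc(N2CCN(c3ccc(OC[C@@H]4CO[C@@](Cn5cncn5)(c5ccc(Cl)cc5Cl)O4)cc3)CC2)cc1` is the next one to be measured. It differs from compound 2 by phenyl in place of benzyl on a saturated chain carbon, two bonds along the chain from a carbonyl carbon, which is the same change cut one bond further out. Within the data shown here, the only measured step that bears on this change is the one from compound 1 to compound 2, where the whole benzyl group was added without a change beyond the scatter. A step of no greater size is therefore expected for compound 3, namely a 1.3-fold lower number from compound 2 to compound 3 (0.10 log units; within the scatter). In this assay compound 3 is estimated at 3000 nM, with a range from 1300 nM to 7000 nM.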

Compound 3, half-maximal inhibitory concentration: 2060 nM
For compound 3 the middle estimate is 1.5-fold (0.16 log units) above the measured one; the range from low to high includes it.
By their numbers in this assay, from the lowest: compounds 3, 1 and 2 (each within the scatter of the next).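

In this assay the step from the 3-phenylpropyl chain to the phenethyl chain is a 1.8-fold lower number from compound 2 to compound 3 (0.26 log units; within the scatter) and stays within the scatter, and so does the step that places phenyl instead of hydrogen on the same saturated chain carbon, a 1.2-fold lower number from compound 1 to compound 3 (0.09 log units; within the scatter) in size. The earlier pair tested only the addition of benzyl at this position, whereas the three compounds together show that neither phenyl nor benzyl there gives a number that can be told apart from the one with hydrogen. No measurement shown here accounts for how close these numbers lie.

Still open, on these data alone, is whether any group at this position can move the number beyond the scatter. An amine or a carboxylic acid in place of the phenyl, or a chain longer than 3-phenylpropyl, would put that to the test.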